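Adding a Second Chlorine to an Aryl Urea

The source may report more compounds than this note shows. Statements on the series, on what has been measured and on what is new or still open speak of the compounds shown alone.

Compound 1, `CCc1cccc(NC(=O)N[C@H](C)c2ccccc2)c1`: 97%
Compound 2, `C[C@@H](NC(=O)Nc1cccc(Cl)c1)c1ccccc1`: 97%
Compound 3, `C[C@@H](NC(=O)Nc1ccc(Cl)c(Cl)c1)c1ccccc1`: 98%

In an ADME assay on the whole organism with Oryza sativa as the target, tested at 0.1 uM (on this read-out lower numbers stand for a stronger effect and higher numbers for a weaker effect at the one concentration tested), compound 2 stands level with compound 1 at the digits shown, and together these two are the lowest of the three numbers; the step of a number 1 percentage points higher from compound 2 to compound 3 (within the scatter) is within the scatter, so all three values sit close together. Compound 4, `C[C@@H](NC(=O)Nc1cc(Cl)cc(Cl)c1)c1ccccc1`, is not yet measured. Against compound 2 the change is chloro in place of hydrogen on an aromatic carbon. Among the compounds with values here, two measured steps bear on this: no change at the digits printed from compound 1 to compound 2 (within the scatter) and a number 1 percentage points higher from compound 2 to compound 3 (within the scatter), the second being the same kind of change, a chloro entering for hydrogen on the same ring. Both were within the scatter, so the expected step is no change at the digits printed from compound 2 to compound 4 (within the scatter), no change beyond the scatter. Compound 4 is therefore estimated at 97%, expected between 89% and 100%.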

Compound 4, a percentage reported as activity, at one concentration (the size of the read-out at that concentration, not a potency): 99%
Compound 4: the middle estimate sits 2 percentage points below what was measured, within the range that was stated.
By their numbers in this assay, from the lowest: compounds 1, 2, 3 and 4 (each within the scatter of the next).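

In this assay, a chloro placed on the aromatic ring, meta to a chloro group already there, leaves compound 4 within the scatter of compound 2 (a number 2 percentage points higher from compound 2 to compound 4 (within the scatter)). This position therefore accepts a second chloro without a change that can be read, as the other position did (a number 1 percentage points higher from compound 2 to compound 3 (within the scatter)). No measurement here offers an explanation for this result.

Still open, from the compounds shown here alone, is whether a different group at this position, such as an amine or a carboxylic acid, would move the number beyond the scatter.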